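Compound 2: expected step on adding methoxy

The source may hold more compounds than are shown below. What is called first, only, known or untested is meant among the compounds shown, and "the series" means these compounds.

In a functional assay on A549 cells (Homo sapiens) for antiproliferative activity, read by MTT assay, with a stated time of 48 h (a higher number here means a weaker inhibitor, a lower number a stronger inhibitor), compound 2 `Oc1ccc2ccccc2c1C(Nc1nc2ccccc2s1)c1cn(-c2ccccc2)nc1-c1ccccc1` gives 36200 nM and lies within the scatter of both compound 1 `O=[N+]([O-])c1cccc(-c2nn(-c3ccccc3)cc2C(Nc2nc3ccccc3s2)c2c(O)ccc3ccccc23)c1` (32000 nM) and compound 3 `Oc1ccc2ccccc2c1C(Nc1nc2ccccc2s1)c1cn(-c2ccccc2)nc1-c1ccc(I)cc1` (23100 nM).

Compound 4 `COc1ccc2nc(NC(c3cn(-c4ccccc4)nc3-c3ccccc3)c3c(O)ccc4ccccc34)sc2c1` has methoxy in place of hydrogen on an aromatic carbon. This turns 1,3-benzothiazol-2-yl into 6-methoxy-1,3-benzothiazol-2-yl, with the new group meta to a fused ring and para to a fused ring.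

Among the compounds with values here, no measured compound carries a substituent on the 1,3-benzothiazol-2-yl group, so the data offer no direct precedent for this change. The nearest guide is the size of the substitution steps elsewhere in the series. Hydrogen in place of nitro gives a small step (a 1.1-fold higher number from compound 1 to compound 2 (0.05 log units; within the scatter)). Iodo in place of hydrogen gives another (a 1.6-fold lower number from compound 2 to compound 3 (0.20 log units; within the scatter)). The exchange of 3-nitrophenyl for 4-iodophenyl gives a third (a 1.4-fold lower number from compound 1 to compound 3 (0.14 log units; within the scatter)). All three stay within the scatter, and they provide no basis for choosing a direction.

No step beyond the scatter is therefore expected in this assay. The estimate corresponds to an expected 1.2-fold lower number from compound 2 to compound 4 (0.07 log units; within the scatter) and remains within the scatter. For compound 4 the expected value is 31000 nM with an estimated range from 14000 nM to 65000 nM as its span.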

Compound 4, half-maximal inhibitory concentration: 44600 nM
Beside the measured number, compound 4's estimate is 1.4-fold (0.16 log units) below it; the measured number falls inside the stated range.
By their numbers in this assay, from the lowest: compounds 3, 1, 2 and 4 (each within the scatter of the next).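

In this assay, within the data shown here, methoxy on the 1,3-benzothiazol-2-yl group, which gives the 6-methoxy-1,3-benzothiazol-2-yl group, produces a 1.2-fold higher number from compound 2 to compound 4 (0.09 log units; within the scatter) and is the first reading of a substituent on this group. The earlier changes, with a 1.1-fold higher number from compound 1 to compound 2 (0.05 log units; within the scatter) and a 1.6-fold lower number from compound 2 to compound 3 (0.20 log units; within the scatter), were all made on a phenyl group, so this result extends the picture of small steps to a second part of the shared core, at this one position and with this one group. No measurement here accounts for the result, which remains an observed step without an explanation.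

The compounds shown leave open whether an amine, a carboxylic acid or a longer alkoxy chain at the same ring position would also stay within the scatter, as methoxy does here. They also leave open whether methoxy on this group would give a similar step when paired with the nitro or iodo substituent of the phenyl series.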